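This account rests on a few compounds, and the source may have more. Where it says the series, first, only, none or still open, it means among the compounds named here.

Of the compounds shown here, three sharing one core have been measured in an in vitro ADME assay on microsomes from liver (Homo sapiens) for metabolic stability; on this read-out higher numbers stand for fast clearance and lower numbers for slow clearance. Compound 1 `CCc1nc2nc(C)cc(Nc3cccc(Cl)c3)n2n1` gives 78.3 mL.min-1.g-1 in this assay. Compound 3 `Cc1cc(Nc2ccc(Cl)cc2)n2nc(C(C)C)nc2n1` gives 14.1 mL.min-1.g-1 in this assay. Compound 2 `CCC(F)(F)c1nc2nc(C)cc(Nc3ccc(S(F)(F)(F)(F)F)cc3)n2n1` is reported in this assay only as a limit, < 5 mL.min-1.g-1, and that reading is not a number. This is the limit of < 5 mL.min-1.g-1 in this assay, at which 1 of the 3 values shown sits, so where compound 2 stands is known only as a limit of the measurement, with no value of its own.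

Compound 4 `COCCc1nc2nc(C)cc(Nc3ccc(S(F)(F)(F)(F)F)cc3)n2n1` has not yet been measured in this assay. It differs from compound 2 in one place: 2-methoxyethyl in place of 1,1-difluoropropyl on an aromatic carbon. Going by the values given here, no pair of measured compounds in this set differs in a single place, so the size of the step from compound 2 to compound 4 cannot be read from any neighbouring pair and can only be expected. The account expects the step from compound 2 to compound 4 to run toward faster clearance and to exceed the usual scatter, amounting to an at least 4.0-fold higher number from compound 2 to compound 4 (0.60 log units; beyond the scatter). Compound 4 is accordingly estimated to give 20 mL.min-1.g-1 in this assay, within a range from 6 mL.min-1.g-1 to 60 mL.min-1.g-1.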

Compound 4, intrinsic clearance in microsomes: 11.5 mL.min-1.g-1
The estimate for compound 4 lay 1.7-fold (0.24 log units) above the measured number; the range from low to high includes it.
By their numbers in this assay, from the lowest: compounds 4 and 3 (each within the scatter of the next); then compound 1. At a limit, below all of these: compound 2.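

With the rest of compound 2 held fixed, the change touches only the aromatic carbon between two ring nitrogen atoms, and 2-methoxyethyl in place of 1,1-difluoropropyl there gives an at least 2.3-fold higher number from compound 2 to compound 4 (0.36 log units; beyond the scatter) in this assay. This step lies beyond the scatter, so the read-out does respond to what sits at this place, something compounds 1 and 3 could not show, as they differ from each other and from compound 2 in more than one place. The full size of the step stays unknown because compound 2 has no value of its own: the limit of < 5 mL.min-1.g-1 in this assay, at which 1 of the 4 values shown sits.

The change removes both fluorine atoms and brings in an oxygen at once, and the compounds shown do not separate these two parts of it. From the compounds shown here alone, how a plain propyl chain, a longer ether chain or an amine at this place would read in this assay remains open, as does whether the step would carry over to the chlorine-bearing compounds 1 and 3.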